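Notes on the step to compound 3

The compounds below may be only part of what the source reports. "The series", "measured", "known", "first", "only" and "open" are said of these compounds alone.

- compound 1 `CC(=O)N[C@@H]1CCC[C@H](C(=O)Nc2cc(-c3cnn4ccccc34)c(Cl)cn2)C1`: 3.6
- compound 2 `CC(=O)N[C@@H]1CCC[C@H](C(=O)Nc2cc(-c3nnn4ccccc34)c(Cl)cn2)C1`: 2

In a physicochemical assay for lipophilicity, using the shake flask method, measured as octanol-water partition, at pH 7.4 (on this read-out higher numbers stand for higher lipophilicity and lower numbers for lower lipophilicity), compound 2, at 2, holds the lower of the two numbers, and compound 1 lies higher at 3.6. Compound 3 `CC(=O)N[C@@H]1CCC[C@H](C(=O)Nc2cc(-c3cnc4n3CCC4)c(Cl)cn2)C1` is still unmeasured and differs from compound 2 at a single place: a group of 8 heavy atoms (6 carbon, 2 nitrogen; one five-membered non-aromatic ring with 1 hetero atom, one five-membered aromatic ring with 2 hetero atoms) in place of a group of 9 heavy atoms (6 carbon, 3 nitrogen; one five-membered aromatic ring with 3 hetero atoms, one six-membered aromatic ring with 1 hetero atom), on an aromatic carbon. The group that enters carries a five-membered non-aromatic ring and no six-membered aromatic ring, so neither measured compound contains it.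

For the measured compounds named here, only one measured step bears on this change, an exchange at the same aromatic carbon: a number 1.60 log units lower from compound 1 to compound 2 (beyond the scatter). That step is large and beyond the scatter. It shows that exchange at this place can move this assay substantially, but it does not fix the direction for a different group. With a single step as a guide, the evidence is thin and the range must stay wide.

A small rise is expected, which may not clear the scatter: a number 0.20 log units higher from compound 2 to compound 3 (within the scatter). For compound 3 the estimated value is 2.2, with an expected range of 1.6 to 2.9.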

Compound 3, distribution coefficient: 2.6
Compound 3: the middle estimate sits 0.40 log units below what was measured; the range from low to high includes it.
By their numbers in this assay, from the lowest: compound 2; then compound 3; then compound 1.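

In this assay, a group with a five-membered non-aromatic ring and no six-membered aromatic ring also shifts the read-out at this aromatic carbon, opposite the ring nitrogen, and it lands between the two earlier groups: there is a number 0.60 log units higher from compound 2 to compound 3 (beyond the scatter) and a number 1.00 log units lower from compound 1 to compound 3 (beyond the scatter). Both steps are beyond the scatter, so the three groups at this place are separated from one another. The nitrogen count in the group does not set the number on its own, as the groups of compound 1 and compound 3 each hold 2 nitrogen atoms yet stand apart, and no measurement on hand speaks to the origin of these steps.

Each step changes ring size, ring saturation and atom make-up together, so the compounds shown cannot assign the shift to any one of these features. Also open, as far as these compounds go, is how the read-out would respond to an amine or a carboxylic acid on the five-membered non-aromatic ring, or whether these steps would keep their size with another group in place of the chloro group.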